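This account rests on a few compounds, and the source may have more. Where it says the series, first, only, none or still open, it means among the compounds named here.

In a functional assay on T47D cells (Homo sapiens) for inhibition (a lower number here means a stronger inhibitor, a higher number a weaker inhibitor), compound 1 (`Oc1ccccc1-c1cc(-c2ccccc2F)cc(-c2ccccc2O)n1`) gives > 50000 nM as its result, and this is a limit of the assay, not a number. Compound 2 (`Oc1ccc(-c2cc(-c3ccccc3F)cc(-c3ccccc3O)n2)cc1`) gives > 50000 nM as its result, likewise a limit. Compound 1 therefore has no readable potency, and the whole record so far is this: the limit of > 50000 nM in this assay, at which 2 of the 2 values shown sit (no value shown is a number).

The change under study leads to compound 3 (`Oc1ccccc1-c1cc(-c2ccccc2C(F)(F)F)cc(-c2ccccc2O)n1`), which carries trifluoromethyl in place of fluoro on an aromatic carbon, ortho to a large group (trifluoromethyl in place of fluoro on an aromatic carbon). Within the data shown here, the only measured step is a step that the two limits leave unreadable from compound 1 to compound 2 and it concerns another group, 4-hydroxyphenyl in place of 2-hydroxyphenyl. With its size unreadable, it gives no measure for this change, so no direction can be argued and no shift beyond the scatter is expected in this assay. The expected result is a number no higher from compound 1 to compound 3 (the limit leaves the size open) as an estimated step. For compound 3 the estimated value is 50000 nM (expected range 10000 nM to 100000 nM) in this assay, and a result reported only as a limit is also likely.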

Compound 3, half-maximal inhibitory concentration: 22500 nM
The estimate for compound 3 lay 2.2-fold (0.35 log units) above the measured number; low and high end bracket the measured number.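

Compound 3 gives the first readable potency in this set: in this assay, trifluoromethyl in place of fluoro on an aromatic carbon, ortho to a large group, gives an at least 2.2-fold lower number from compound 1 to compound 3 (0.34 log units; beyond the scatter). Among these compounds, the earlier pair could not show that this position responds to a change of substituent, as the one step between them, from compound 1 to compound 2, cannot be read; the new step shows that it does, and that the core of compound 1 can reach a measurable number in this assay with both of its 2-hydroxyphenyl groups left in place. Compound 1 and compound 2 remain at a limit of the assay rather than a number, so the true size of the step stays open at its upper end: the limit of > 50000 nM in this assay, at which 2 of the 3 values shown sit.

The compounds shown leave open whether the lower number belongs to trifluoromethyl itself or would also appear with a chlorine atom, a methyl group or a nitrile at the same place. They also leave open whether 4-hydroxyphenyl in place of 2-hydroxyphenyl would give a readable step when trifluoromethyl is present.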